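Adding Ethyl to Compound 2

This account rests on a few compounds, and the source may have more. Where it says the series, first, only, none or still open, it means among the compounds named here.

In a functional assay on artery with platelet-activating factor receptor (Rattus norvegicus) as the target (a lower number here means that less compound is needed, a higher number that more compound is needed for the effect), compound 2 `CCCCCCCCCCCCCCOCC1COC(COCCCCCC[n+]2ccsc2)C1` gives 3.1 mg/kg.
In this assay compound 3 `CCCCCCCCCCCCCCOCC1COC(COCCCCCCC[n+]2ccsc2)C1` gives 1.4 mg/kg.
Compound 1 `CCCCCCCCCCCCCCCCCC1OCC(COCCCCCC[n+]2ccccc2)O1` gives only a limit in this assay, > 5 mg/kg.

Among the two numbers shown, compound 2 stands highest; its nearest neighbour is compound 3, reached by a 2.2-fold lower number from compound 2 to compound 3 (0.35 log units; beyond the scatter), a step that lies beyond the scatter of repeated measurements. Compound 4 `CCCCCCCCCCCCCCCCOCC1COC(COCCCCCC[n+]2ccsc2)C1` is the one still to be measured. It differs from compound 2 by ethyl in place of hydrogen on a saturated chain carbon, ten or more bonds along the chain from an oxygen on a saturated carbon.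

For the measured compounds named here, none of the measured steps touches this kind of change. Going by the values given here, the single measured step, a 2.2-fold lower number from compound 2 to compound 3 (0.35 log units; beyond the scatter), concerns the five-membered aromatic ring at the other end of the molecule and says nothing about the saturated chain. Among the compounds with values here, compound 1 carries a different core and gives only a limit, so it offers no step to compare. With no guidance from the data, the step of a 1.0-fold lower number from compound 2 to compound 4 (0.01 log units; within the scatter) is expected to stay within the scatter, in no particular direction. Compound 4 is therefore estimated at 3 mg/kg, with a range from 1 mg/kg to 9 mg/kg.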

Compound 4, dose for 50% inhibition: 1.2 mg/kg
Compound 4: the middle estimate sits 2.5-fold (0.40 log units) above what was measured, and the stated range covers the measured number.
By their numbers in this assay, from the lowest: compounds 4 and 3 (each within the scatter of the next); then compound 2. At a limit, above all of these: compound 1.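

In this assay, the far end of the saturated chain proves to be a position that responds to change: ethyl in place of hydrogen on a saturated chain carbon gives a 2.6-fold lower number from compound 2 to compound 4 (0.41 log units; beyond the scatter). For the compounds shown here, the step is modest, but it is the first measured change at this end of the molecule, as the earlier step, a 2.2-fold lower number from compound 2 to compound 3 (0.35 log units; beyond the scatter), concerned the other end. Nothing among the data shown explains why the added ethyl lowers the number.

A single step cannot show whether a longer chain, such as propyl or butyl in place of hydrogen at this position, would lower the number further or raise it again. The compounds shown also leave open how a hydroxyl or a carboxylic acid at the end of the chain would behave.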